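Pyridin-3-yl in place of 3-(trifluoromethyl)phenyl: cytotoxicity notes

A few compounds are considered here, and "the series" means these few. Any claim that something is new, unique, unknown or untested is made for them only; others in the source may bear on it.

Compound 1 (`O=Cc1ccc(-c2cc(Cl)cn3c([N+](=O)[O-])c(CS(=O)(=O)c4ccccc4)nc23)cc1`) and compound 2 (`O=[N+]([O-])c1c(CS(=O)(=O)c2ccccc2)nc2c(-c3cccc(C(F)(F)F)c3)cc(Cl)cn12`) share a core. In an ADME assay on HepG2 cells (Homo sapiens) for cytotoxicity, read by MTT assay, with a stated time of 72 h (a higher number here means that more compound is tolerated, a lower number that less compound is tolerated), compound 1 gives > 31200 nM as a limit. In this assay compound 2 gives > 12500 nM as a limit too, so it stands at no exact number. Compound 3 (`O=[N+]([O-])c1c(CS(=O)(=O)c2ccccc2)nc2c(-c3cccnc3)cc(Cl)cn12`) differs by pyridin-3-yl in place of 3-(trifluoromethyl)phenyl on an aromatic carbon on that aromatic carbon. Among the measured compounds shown here, the only measured step bearing on this is a step that the two limits leave unreadable from compound 1 to compound 2 with 3-(trifluoromethyl)phenyl in place of 4-formylphenyl, and it fixes no size. Nothing beyond the scatter is therefore expected, and the estimated step is a step that the limit leaves unreadable from compound 2 to compound 3 in either direction. Compound 3 is expected at 20000 nM in this assay (estimated range 7000 nM to 50000 nM).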

Compound 3, half-maximal cytotoxic concentration: > 31300 nM
Compound 3: only a limit was reported; the forecaster's own chance of this, stated with the estimate: 70%; at least 1.5-fold (0.19 log units) between middle value and limit.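

In this assay, among the compounds shown here, compound 1, compound 2 and compound 3 are each reported only as a limit, and no step among them can be read. The compounds shown leave open at what concentration any of the three becomes cytotoxic, and whether 4-formylphenyl, 3-(trifluoromethyl)phenyl and pyridin-3-yl differ at all.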